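Benzofuran-bearing ribosides on the shared core

The source may hold more compounds than are shown below. What is called first, only, known or untested is meant among the compounds shown, and "the series" means these compounds.

Compound 3 `Nc1nc(N)c2c(-c3ccoc3)cn([C@@H]3O[C@H](CO)[C@@H](O)[C@H]3O)c2n1` is known in a functional assay on K562 cells (Homo sapiens), read by MTT assay, with a stated time of 72 h (a lower number here means a stronger inhibitor, a higher number a weaker inhibitor), only as a limit: compound 3 gives > 20000 nM. Compound 2 `Nc1nc(N)c2c(-c3cccs3)cn([C@@H]3O[C@H](CO)[C@@H](O)[C@H]3O)c2n1` likewise reaches only a limit, as compound 2 gives > 20000 nM in this assay. Going by the values given here, the one measured step, a step that the two limits leave unreadable from compound 2 to compound 3, therefore cannot be sized, in line with the limit of > 20000 nM in this assay, at which 2 of the 3 values shown sit. Among the compounds with values here, compound 1 `Cc1nc(N)c2c(-c3cc4ccccc4o3)cn([C@@H]3O[C@H](CO)[C@@H](O)[C@H]3O)c2n1` is the only member with a measured number, as compound 1 gives 15700 nM in this assay.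

Compound 4 `Nc1nc(N)c2c(-c3cc4ccccc4o3)cn([C@@H]3O[C@H](CO)[C@@H](O)[C@H]3O)c2n1` differs from compound 3 by 1-benzofuran-2-yl in place of furan-3-yl on an aromatic carbon. Within the data shown here, no measured step bears directly on this change, since the step from compound 2 to compound 3 remains unreadable. Compound 1 already carries 1-benzofuran-2-yl and differs from compound 4 elsewhere on the shared core, so its value is the nearest guide. Against the limit of compound 3, the step from compound 3 to compound 4 is estimated as an at least 1.6-fold lower number from compound 3 to compound 4 (0.22 log units; that floor lies within the scatter), read as a modest gain, though a result that again ends at a limit cannot be excluded. Compound 4 is therefore expected to give about 12000 nM in this assay, with a range from 4000 nM to 40000 nM.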

Compound 4, half-maximal inhibitory concentration: 18600 nM
The estimate for compound 4 lay 1.6-fold (0.19 log units) below the measured number; the range from low to high includes it.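

The larger 1-benzofuran-2-yl group on this aromatic carbon gives compound 4 a measured number in this assay, whereas compounds 2 and 3, which carry the smaller five-membered rings on the same core, remain at a limit: the limit of > 20000 nM in this assay, at which 2 of the 4 values shown sit. From the compounds shown here alone, the readable floors are an at least 1.0-fold lower number from compound 3 to compound 4 (0.03 log units; that floor lies within the scatter) and an at least 1.0-fold lower number from compound 2 to compound 4 (0.03 log units; that floor lies within the scatter), so the added six-membered aromatic ring gives a measured value but does not establish a gain beyond the scatter, and the true size of either step remains unknown. Going by these compounds alone, the step of a 1.2-fold higher number from compound 1 to compound 4 (0.07 log units; within the scatter) adds what the earlier compounds could not show: with 1-benzofuran-2-yl in place, amino and methyl on the other aromatic carbon of the shared core cannot be told apart in this assay.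

Open, going by these compounds, is whether a substituted 1-benzofuran-2-yl group, for example one carrying a methoxy group, an amine or a carboxylic acid on its six-membered aromatic ring, would move the number clearly beyond the scatter. Also open, on these data alone, is whether methyl in place of amino would leave compounds 2 and 3 at their limits or give a measured value with furan-3-yl or thiophen-2-yl on the aromatic carbon.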